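Chain and ring substituents on a shared core

A few compounds are considered here, and "the series" means these few. Any claim that something is new, unique, unknown or untested is made for them only; others in the source may bear on it.

Measured in a functional assay on brain (Rattus norvegicus, strain Wistar) for inhibition; on this read-out higher numbers stand for weaker inhibition and lower numbers for stronger inhibition:
- compound 1 `Cc1ccc(-c2c(C)[nH]c(=O)n2C)cc1`: 85300 nM
- compound 2 `CCCCCc1ccc(-c2c(C)[nH]c(=O)n2C)cc1`: 5900 nM
- compound 3 `CCCCCCc1ccc(-c2c(C)[nH]c(=O)n2C)cc1`: 9000 nM

Compound 3 lies within the scatter of compound 2, with a 1.5-fold higher number from compound 2 to compound 3 (0.18 log units; within the scatter), and well under compound 1, with a 9.5-fold lower number from compound 1 to compound 3 (0.98 log units; beyond the scatter). Compound 4 `Cc1[nH]c(=O)n(C)c1-c1ccc(C2CCCCC2)cc1` has cyclohexyl in place of hexyl on an aromatic carbon. The nearest measured changes at this place are a 14-fold lower number from compound 1 to compound 2 (1.16 log units; beyond the scatter) and a 1.5-fold higher number from compound 2 to compound 3 (0.18 log units; within the scatter). Among the compounds with values here, no measured compound carries a ring here, so the range stays wide. In this assay, no step beyond the scatter is expected, and the expected step is a 1.1-fold lower number from compound 3 to compound 4 (0.05 log units; within the scatter). For compound 4 the estimate is 8000 nM, with an expected range of 3000 nM to 25000 nM.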

Compound 4, half-maximal inhibitory concentration: 10000 nM
For compound 4 the middle estimate is 1.3-fold (0.10 log units) below the measured one, and the stated range covers the measured number.
By their numbers in this assay, from the lowest: compounds 2, 3 and 4 (each within the scatter of the next); then compound 1.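

In this assay, a saturated ring can stand at this position in place of an open chain: cyclohexyl gives a 1.1-fold higher number from compound 3 to compound 4 (0.05 log units; within the scatter) against hexyl and a 1.7-fold higher number from compound 2 to compound 4 (0.23 log units; within the scatter) against pentyl, and still shows an 8.5-fold lower number from compound 1 to compound 4 (0.93 log units; beyond the scatter) against methyl. The lower number relative to compound 1 therefore does not require an open chain among the compounds shown, as pentyl, hexyl and cyclohexyl all lie within the scatter of one another. No supporting data bear on this result.

Open, on these data alone, is how ethyl or butyl would fall between methyl and pentyl. Also open, as far as these compounds go, is whether a phenyl ring, or a cyclohexyl ring carrying an amine, would hold these numbers.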